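Moving Fluorine Around the Benzyl Group of Compound 2

This account rests on a few compounds, and the source may have more. Where it says the series, first, only, none or still open, it means among the compounds named here.

Compound 1 `Cc1cccc(CN2CCC(c3noc(COc4ccc(/C=C/C(=O)NO)cc4)n3)CC2)c1` — 73%
Compound 2 `O=C(/C=C/c1ccc(OCc2nc(C3CCN(Cc4ccc(F)cc4F)CC3)no2)cc1)NO` — 74%

Of the compounds shown here, two have been measured in an assay on isolated protein for inhibition of protein deacetylase HDAC6 (Homo sapiens), read by fluorescence, with a stated time of 1 h, tested at 100 nM; a higher number here means more inhibition at the concentration tested (going by the name of the read-out), a lower number less inhibition. Compound 1 gives 73%, and compound 2 gives 74%. Of the two numbers, that of compound 2 is the higher, but the gap to compound 1 lies within the scatter, so no order between them can be claimed. Going by the values given here, the single measured step, a number 1 percentage points higher from compound 1 to compound 2 (within the scatter), exchanges the aromatic group on the saturated chain carbon bound to an amine nitrogen in a ring and stays within the scatter.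

Compound 3 `O=C(/C=C/c1ccc(OCc2nc(C3CCN(Cc4ccc(F)c(F)c4)CC3)no2)cc1)NO` is the next member. It differs from compound 2 by 3,4-difluorophenyl in place of 2,4-difluorophenyl on a saturated chain carbon bound to an amine nitrogen in a ring. Among the compounds with values here, this is again an exchange of the aromatic group at the same place, and the only step bearing on it, a number 1 percentage points higher from compound 1 to compound 2 (within the scatter), was within the scatter; a step of no more than the scatter is therefore expected, a number 2 percentage points lower from compound 2 to compound 3 (within the scatter). Compound 3 is estimated at 72% in this assay, with a range from 58% to 84%.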

Compound 3, a percentage reported as inhibition, at one concentration (the size of the read-out at that concentration, not a potency): 60%
Compound 3: middle estimate off by 12 percentage points, on the high side; the measured number falls inside the stated range.
By their numbers in this assay, from the lowest: compound 3; then compounds 1 and 2 (each within the scatter of the next).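

The position on the saturated chain carbon bound to an amine nitrogen in a ring, where the earlier step stayed within the scatter, now proves able to change the read-out in this assay. With the atoms unchanged and only the fluorine arrangement differing, 3,4-difluorophenyl in place of 2,4-difluorophenyl gives a number 14 percentage points lower from compound 2 to compound 3 (beyond the scatter), so the arrangement of the two fluorines matters here and not just their presence; the same group in place of 3-methylphenyl gives a number 13 percentage points lower from compound 1 to compound 3 (beyond the scatter). No measurement at hand explains this difference.

From the compounds shown here alone, it remains open whether a plain phenyl, 4-fluorophenyl or 3-fluorophenyl group would read like compound 2 or like compound 3. Going by these compounds, whether a single concentration captures the full size of these differences also remains open.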